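A Bromo Step Repeated on a Hydroxy-Bearing Analogue

A few compounds are considered here, and "the series" means these few. Any claim that something is new, unique, unknown or untested is made for them only; others in the source may bear on it.

Of the compounds shown here, three built on one shared core have been measured in a functional assay on cells (Erythrocyte, Homo sapiens) for inhibition, read by spectrophotometry and hemolysis, with a stated time of 10 min; on this read-out higher numbers stand for weaker inhibition and lower numbers for stronger inhibition. Compound 1, `Cc1cccc2nc(N/N=C\c3ccccc3)sc12`, gives 80.1 ug/mL in this assay. Compound 2, `Cc1cccc2nc(N/N=C\c3ccc(Br)cc3)sc12`, carries bromo in place of hydrogen on an aromatic carbon and in this assay gives 20.1 ug/mL, which is a 4.0-fold lower number from compound 1 to compound 2 (0.60 log units; beyond the scatter). Compound 3, `Cc1cccc2nc(N/N=C\c3ccc(O)cc3)sc12`, differs from compound 1 by hydroxy in place of hydrogen on an aromatic carbon. In this assay compound 3 gives 60 ug/mL, a change of a 1.3-fold lower number from compound 1 to compound 3 (0.13 log units; within the scatter). Between these two substituted compounds the step is a 3.0-fold higher number from compound 2 to compound 3 (0.47 log units; beyond the scatter).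

Compound 4, `Cc1cccc2nc(N/N=C\c3ccc(O)c(Br)c3)sc12`, has not been measured in this assay. It differs from compound 3 by bromo in place of hydrogen on an aromatic carbon. Going by the values given here, this is the same kind of change as the one from compound 1 to compound 2, but not the same change: in compound 2 the bromo sits para to a large group, while in compound 4 it sits ortho to a hydroxy group and meta to a large group. Among the compounds with values here, the bromo step measured so far is a 4.0-fold lower number from compound 1 to compound 2 (0.60 log units; beyond the scatter), and that single step is the only guide available; the surroundings of the new place are not the same, which argues for caution.

Compound 4 is therefore expected to show a 2.4-fold lower number from compound 3 to compound 4 (0.38 log units; beyond the scatter) in this assay. In this assay compound 4 is estimated at 25 ug/mL, with a likely range from 10 ug/mL to 60 ug/mL.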

Compound 4, half-maximal inhibitory concentration: 52.4 ug/mL
Compound 4: the middle estimate sits 2.1-fold (0.32 log units) below what was measured, within the range that was stated.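

Placed on compound 3, bromo in place of hydrogen on an aromatic carbon gives a 1.1-fold lower number from compound 3 to compound 4 (0.06 log units; within the scatter) in this assay, so on this hydroxy-bearing compound the change leaves the read-out within the usual scatter. Set beside the earlier bromo step, this shows that the change does not carry over at a constant size from one core to the other in this series: the same change on two cores in this assay, a 4.0-fold lower number (0.60 log units; beyond the scatter) from compound 1 to compound 2 and a 1.1-fold lower number (0.06 log units; within the scatter) from compound 3 to compound 4, 3.5-fold (0.54 log units) apart, beyond the scatter of two such steps

What the comparison does not show is the reason for the gap: the new bromo stands ortho to a hydroxy group and meta to a large group, so place and surroundings differ together, and two steps cannot separate them or give a rule for any further core.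

The compounds shown leave open whether bromo at this same place on the core of compound 1, with no hydroxy group present, would follow the step from compound 1 to compound 2 or the one from compound 3 to compound 4. They also leave open how bromo would behave on an analogue that carries a methoxy group or an amine in place of the hydroxy group.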